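The compounds below may be only part of what the source reports. "The series", "measured", "known", "first", "only" and "open" are said of these compounds alone.

Measured so far in an ADME assay on HeLa cells (Homo sapiens) for cytotoxicity, read by MTT assay; on this read-out higher numbers stand for weaker inhibition and lower numbers for stronger inhibition:
- compound 1 `COc1ccc(C[C@H]2COC(=O)[C@@H]2Cc2ccc(OCc3cn(-c4ccc(Br)cc4)nn3)c(OC)c2)cc1OC`: 128000 nM
- compound 2 `COc1ccc(C[C@H]2COC(=O)[C@@H]2Cc2ccc(OCc3cn(-c4ccc(C)cc4)nn3)c(OC)c2)cc1OC`: >= 600000 nM

Compound 2 gives >= 600000 nM, which is a limit and not a number. Its standing in the series is therefore known only as a limit: the limit of >= 600000 nM in this assay, at which 1 of the 2 values shown sits.

Compound 3 `COc1ccc(-n2cc(COc3ccc(C[C@H]4C(=O)OC[C@@H]4Cc4ccc(OC)c(OC)c4)cc3OC)nn2)cc1` has methoxy in place of methyl on an aromatic carbon, para to a large group: methoxy in place of methyl on an aromatic carbon. The same difference reads 4-methylphenyl to 4-methoxyphenyl.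

Among the compounds with values here, one measured step bears on this change: an at least 4.6-fold higher number from compound 1 to compound 2 (0.67 log units; beyond the scatter), with methyl in place of bromo on that same aromatic carbon. Within the data shown here, its full size is hidden by the limit, and no measured compound carries methoxy, so the guidance is thin. Compound 1 at 128000 nM shows that a change on this carbon alone can move the number. A modest move toward lower numbers in this assay is expected, though compound 3 could also return a limit. The expected change is an at least 2.0-fold lower number from compound 2 to compound 3 (0.30 log units; that floor lies within the scatter). The estimate for compound 3 is 300000 nM, with an expected range from 100000 nM to 700000 nM.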

Compound 3, half-maximal inhibitory concentration: >= 600000 nM
Compound 3 gave a limit, no number; the forecaster's own chance of this, stated with the estimate: 40%; at least 2.0-fold (0.30 log units) between middle value and limit.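

In this assay compound 3 gives >= 600000 nM, a limit and not a number. Methoxy in place of bromo on this aromatic carbon gives an at least 4.6-fold higher number from compound 1 to compound 3 (0.67 log units; beyond the scatter), so a second replacement of bromo now also moves the read-out beyond the scatter, and among the three 4-substituted phenyl compounds only the bromo compound, compound 1, returns a number. The change from 4-methylphenyl to 4-methoxyphenyl cannot be read, and methyl and methoxy cannot be ranked against each other, as both compounds stand at the same limit: the limit of >= 600000 nM in this assay, at which 2 of the 3 values shown sit.

As far as these compounds go, how far compound 2 and compound 3 lie beyond that limit stays open, and so does any difference between them. Also open, from the compounds shown here alone, is whether a number on this read-out belongs to bromo alone or extends to other groups on the same aromatic carbon, such as chloro, an amine or a carboxylic acid.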